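Amino in Place of Chloro: An Expected Gain in Potency

A few compounds are considered here, and "the series" means these few. Any claim that something is new, unique, unknown or untested is made for them only; others in the source may bear on it.

Of the compounds shown here, three have been measured in a functional assay on MOLT-4 cells (Homo sapiens) for cytotoxicity, read by sulforhodamine B assay, with a stated time of 48 h; a higher number here means a weaker inhibitor of growth, a lower number a stronger inhibitor of growth. Compound 1 `Nc1nc(Cl)c2ncn(Cc3ccc(CCl)cc3)c2n1` gives 2950 nM, compound 2 `ClCc1cccc(Cn2cnc3c(Cl)nc(Cl)nc32)c1` gives 3380 nM, and compound 3 `ClCc1ccc(Cn2cnc3c(Cl)nc(Cl)nc32)cc1` gives 10500 nM. Compound 1 and compound 2 lie within the scatter of each other. The change from compound 3 to compound 1 is amino in place of chloro on an aromatic carbon, and it made a 3.6-fold lower number from compound 3 to compound 1 (0.55 log units; beyond the scatter). Compound 2 and compound 3 are built from the same atoms joined differently; the difference between the two cores is not broken down here. Compound 4 `Nc1nc(Cl)c2ncn(Cc3cccc(CCl)c3)c2n1` has not yet been measured. It differs from compound 2 by amino in place of chloro on an aromatic carbon, the same change as that from compound 3 to compound 1. Because that earlier change gave a 3.6-fold lower number from compound 3 to compound 1 (0.55 log units; beyond the scatter), compound 4 is expected to show a 3.2-fold lower number from compound 2 to compound 4 (0.51 log units; beyond the scatter) in this assay. Compound 4 is therefore estimated at 1050 nM, within a range from 400 nM to 3000 nM.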

Compound 4, concentration for 50% growth inhibition: 4780 nM
For compound 4 the middle estimate is 4.6-fold (0.66 log units) below the measured one; the whole stated range lies below it.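

In this assay the change of amino in place of chloro on an aromatic carbon gave a 1.4-fold higher number from compound 2 to compound 4 (0.15 log units; within the scatter) and so did not repeat the drop in number seen on the core of compound 3. The two steps do not agree: the same change on two cores in this assay, a 3.6-fold lower number (0.55 log units; beyond the scatter) from compound 3 to compound 1 and a 1.4-fold higher number (0.15 log units; within the scatter) from compound 2 to compound 4, 5.0-fold (0.70 log units) apart, beyond the scatter of two such steps. In this series, then, the step measured on one core was no reliable guide to the step on the other, but two pairs cannot show what separates the cores or how the change would behave on a further one.

The compounds shown leave open whether another group at that aromatic carbon, such as a methylamino or a hydroxyl group, would give the same step on both cores.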